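The source may hold more compounds than are shown below. What is called first, only, known or untested is meant among the compounds shown, and "the series" means these compounds.

Measured so far in a functional assay on cells (Splenocyte, Mus musculus, strain BALB/c) for inhibition, read by scintillation counting and thymidine incorporation, with stated times of 48 h and 8 h; on this read-out lower numbers stand for stronger inhibition and higher numbers for weaker inhibition:
compound 1 `COc1ccccc1-c1nc(Cc2c[nH]c3ccccc23)no1` gives 11100 nM
compound 2 `COc1ccc(-c2nc(Cc3c[nH]c4ccccc34)no2)cc1` gives only a limit, > 50000 nM

Compound 2 stands at the limit of this assay: for it only a limit and no number is known, as the limit of > 50000 nM in this assay, at which 1 of the 2 values shown sits, shows. Compound 1, the other measured compound, gives a number, 11100 nM in this assay. Within the data shown here, no step between measured compounds that differ in one place is available, so the two values can only be set side by side.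

Compound 3 `COc1ccc(-c2nc(Cc3c[nH]c4ccccc34)no2)c(OC)c1` has not yet been measured. It differs from compound 2 in one place: methoxy in place of hydrogen on an aromatic carbon. Since compound 2 is known only as a limit, the size of the step cannot be read from the data; a modest gain, within or a little beyond the scatter, is expected, an at least 2.0-fold lower number from compound 2 to compound 3 (0.30 log units; that floor lies within the scatter). Compound 3 is expected to give about 25000 nM in this assay, with a range from 5000 nM to 100000 nM.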

Compound 3, half-maximal inhibitory concentration: 4700 nM
For compound 3 the middle estimate is 5.3-fold (0.73 log units) above the measured one, outside the stated range (below it).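

In this assay, methoxy in place of hydrogen on an aromatic carbon, ortho to a large group, gives an at least 10-fold lower number from compound 2 to compound 3 (1.02 log units; beyond the scatter), so this position responds strongly to the change in a way that compound 1 and compound 2 alone could not show. The step that adds the other methoxy group gives a 2.4-fold lower number from compound 1 to compound 3 (0.37 log units; beyond the scatter), so compound 3, which carries both methoxy groups, has a lower number than either compound with one of them. The first step can be given only as a floor, because compound 2 is known only as a limit: the limit of > 50000 nM in this assay, at which 1 of the 3 values shown sits.

The compounds shown leave open whether a different group at this position, such as a hydroxyl, a chlorine or an amine, would give a similar gain. Also open, on these data alone, is whether a longer chain, such as ethoxy, would keep it.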